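From 3-chlorophenoxy to cyclohexyloxy on the shared core

A few compounds are considered here, and "the series" means these few. Any claim that something is new, unique, unknown or untested is made for them only; others in the source may bear on it.

Compound 1 (`Cc1cn(C2CCN(Cc3cccc(Oc4ccc(F)c(F)c4)c3)CC2)c(=O)[nH]c1=O`) gives > 64000 nM in an ADME assay on MRC5 cells (Homo sapiens) for cytotoxicity, read by fluorescence and resazurin assay, with a stated time of 3 days (on this read-out higher numbers stand for weaker inhibition and lower numbers for stronger inhibition), a limit of the assay and not a number.

Going by the values given here, compound 2 (`Cc1cn(C2CCN(Cc3cccc(Oc4cccc(Cl)c4)c3)CC2)c(=O)[nH]c1=O`) gives 21000 nM in this assay, the only exact number so far.

Among the compounds with values here, the one measured step is an at least 3.0-fold lower number from compound 1 to compound 2 (0.48 log units; beyond the scatter). From the compounds shown here alone, its full size stays open because of the limit of > 64000 nM in this assay, at which 1 of the 2 values shown sits.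

Compound 3 (`Cc1cn(C2CCN(Cc3cccc(OC4CCCCC4)c3)CC2)c(=O)[nH]c1=O`) follows from compound 2 by a single change, cyclohexyl in place of 3-chlorophenyl on an oxygen on an aromatic ring. The same place changed in the measured step, so the group on this oxygen can move the read-out, as an at least 3.0-fold lower number from compound 1 to compound 2 (0.48 log units; beyond the scatter) shows. Within the data shown here, that step, however, exchanged one substituted phenyl for another, and no measured pair replaces the aromatic ring with a non-aromatic one. It therefore gives no direction for the present change, and no shift beyond the scatter is expected in this assay.

The estimated step is a 1.2-fold higher number from compound 2 to compound 3 (0.08 log units; within the scatter).

For compound 3 the expected value is 25000 nM, with an estimated range of 9000 nM to 64000 nM.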

Compound 3, half-maximal inhibitory concentration: 23600 nM
The estimate for compound 3 lay 1.1-fold (0.03 log units) above the measured number, within the range that was stated.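

In this assay, replacing the aromatic ring on this oxygen with a non-aromatic one gives a 1.1-fold higher number from compound 2 to compound 3 (0.05 log units; within the scatter), so for this pair the read-out does not depend on that ring being aromatic or carrying chlorine. The comparison with the 3,4-difluorophenyl group gives an at least 2.7-fold lower number from compound 1 to compound 3 (0.43 log units; beyond the scatter), which places cyclohexyl and 3-chlorophenyl together on the same side of that group, and among the three groups on this oxygen only 3,4-difluorophenyl stands apart. Compound 1 gives a limit and not a number, so the full size of this step stays open: the limit of > 64000 nM in this assay, at which 1 of the 3 values shown sits.

The compounds shown leave open whether the read-out holds when the group on this oxygen carries an amine or a carboxylic acid, or when the ring gives way to a longer alkyl chain. They also leave open how an unsubstituted phenyl on this oxygen would read, which would help show whether the separation of the 3,4-difluorophenyl group belongs to its fluorines or to the phenyl ring that carries them.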